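Swapping a Difluorophenyl for a Methoxyphenyl on a Sulfonamide

The source may hold more compounds than are shown below. What is called first, only, known or untested is meant among the compounds shown, and "the series" means these compounds.

Of the compounds shown here, two that share a core have been tested in a functional assay on M21 cells (Homo sapiens) for antiproliferative activity, read by sulforhodamine B assay, with a stated time of 48 h; a higher number here means a weaker inhibitor, a lower number a stronger inhibitor. Compound 1 `O=C1NCCN1c1ccc(S(=O)(=O)Nc2ccc(F)c(F)c2)cc1` gives 220 nM in this assay. Compound 2 `O=C1NCCN1c1ccc(S(=O)(=O)Nc2ccc3c(c2)CCC3)cc1` gives 130 nM in this assay. Compound 1 has the higher of the two numbers, but its gap to compound 2 lies within the usual scatter of repeated measurements, so no real difference between these two compounds can be claimed.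

Compound 3 `COc1ccc(NS(=O)(=O)c2ccc(N3CCNC3=O)cc2)cc1` has not yet been measured. It differs from compound 1 in one place: 4-methoxyphenyl in place of 3,4-difluorophenyl on a sulfonamide nitrogen.

For the measured compounds named here, the two measured compounds differ from each other in a different way, so nothing measured so far shows what this particular exchange does. The step from compound 1 to compound 3 is therefore expected to be small, no change at the digits printed from compound 1 to compound 3 (within the scatter), with no clear direction beyond the scatter. Compound 3 is estimated to give 220 nM in this assay, within a range from 80 nM to 600 nM.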

Compound 3, half-maximal inhibitory concentration: 580 nM
The estimate for compound 3 lay 2.6-fold (0.42 log units) below the measured number; low and high end bracket the measured number.
By their numbers in this assay, from the lowest: compounds 2 and 1 (each within the scatter of the next); then compound 3.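

In this assay, the group on the sulfonamide nitrogen clearly matters: 4-methoxyphenyl in place of 3,4-difluorophenyl gives a 2.6-fold higher number from compound 1 to compound 3 (0.42 log units; beyond the scatter) and so a weaker inhibitor, a step beyond the scatter. The group that leaves and the group that enters have the same count of heavy atoms and each holds one six-membered aromatic ring, so the number can move even when those counts stay equal. Nothing at hand explains why this exchange moves the number.

Because the fluorines leave and the methoxy group enters in one step, the compounds shown cannot separate what each change contributes. Going by these compounds, how a plain phenyl ring, or a ring carrying an amine or a carboxylic acid, would behave on this nitrogen also remains open.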